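From fluoro to methyl at the limit of the assay

The source may report more compounds than this note shows. Statements on the series, on what has been measured and on what is new or still open speak of the compounds shown alone.

Values in a functional assay on MCF7 cells (Homo sapiens) for antiproliferative activity, read by MTT assay, with a stated time of 72 h; on this read-out higher numbers stand for weaker inhibition and lower numbers for stronger inhibition:
- compound 1 `C=CC(=O)Nc1cccc(Oc2nc(Nc3ccn(C)n3)nc3c2CSCC3)c1`: > 50000 nM
- compound 2 `C=C(F)C(=O)Nc1cccc(Oc2nc(Nc3ccn(C)n3)nc3c2CSCC3)c1`: > 50000 nM

Compound 2 stands at a limit of this assay, > 50000 nM, and has no exact number. Compound 1 is also a limit, > 50000 nM. Together they show (the limit of > 50000 nM in this assay, at which 2 of the 2 values shown sit).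

Compound 3 `C=C(C)C(=O)Nc1cccc(Oc2nc(Nc3ccn(C)n3)nc3c2CSCC3)c1` carries methyl in place of fluoro on a double-bonded chain carbon bound to a carbonyl carbon. Among the measured compounds shown here, the only measured step at that place is a step that the two limits leave unreadable from compound 1 to compound 2, so it offers no size to carry over. No readable step is therefore expected in this assay, and no direction can be given. Compound 3 is estimated at 50000 nM, with an expected range of 20000 nM to 100000 nM. The estimated a number no higher from compound 2 to compound 3 (the limit leaves the size open) is only nominal, and a further limit is the likeliest result.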

Compound 3, half-maximal inhibitory concentration: > 50000 nM
Compound 3: no number, only a limit; the forecaster's own chance of this, stated with the estimate: 85%; the middle value sits exactly at the limit.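

No new step can be read among compound 1, compound 2 and compound 3, because all three sit at the same limit: the limit of > 50000 nM in this assay, at which 3 of the 3 values shown sit.

The compounds shown leave open how hydrogen, fluoro and methyl on a double-bonded chain carbon bound to a carbonyl carbon compare in antiproliferative strength.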